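Lengthening the alkyl chain from compound 2 toward compound 1

A few compounds are considered here, and "the series" means these few. Any claim that something is new, unique, unknown or untested is made for them only; others in the source may bear on it.

Among the measured compounds shown here, compound 2 `CCCCc1ccc(NC(=O)Nc2c(C(C)C)cccc2C(C)C)cc1` gives 29 nM in an assay on isolated protein for inhibition of acyl-CoA:cholesterol acyltransferase (Oryctolagus cuniculus) (a higher number here means a weaker inhibitor, a lower number a stronger inhibitor), the highest of the two numbers so far; compound 1 `CCCCCCCCCCCCCc1ccc(NC(=O)Nc2c(C(C)C)cccc2C(C)C)cc1` gives 11 nM. For the measured compounds named here, the one measured step, a 2.6-fold higher number from compound 1 to compound 2 (0.42 log units; beyond the scatter), bears directly on the change at hand. Compound 3 `CCCCCCCCCc1ccc(NC(=O)Nc2c(C(C)C)cccc2C(C)C)cc1` carries pentyl in place of hydrogen on a saturated chain carbon, four bonds along the chain from an aromatic carbon, which places its chain between those of compound 2 and compound 1. A lower number is therefore expected, most of the way toward compound 1. For compound 3 the expected step is a 1.9-fold lower number from compound 2 to compound 3 (0.29 log units; within the scatter). For compound 3 the estimate in this assay is 15 nM, with a range from 7 nM to 35 nM.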

Compound 3, half-maximal inhibitory concentration: 9 nM
Estimate against measurement, compound 3: 1.7-fold (0.22 log units) above; the range from low to high includes it.
By their numbers in this assay, from the lowest: compounds 3 and 1 (each within the scatter of the next); then compound 2.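

In this assay, pentyl in place of hydrogen at this saturated chain carbon gives a gain beyond the scatter (a 3.2-fold lower number from compound 2 to compound 3 (0.51 log units; beyond the scatter)). Hydrogen in place of butyl further along the chain gives no readable change (a 1.2-fold lower number from compound 1 to compound 3 (0.09 log units; within the scatter)), so among these compounds, the longer chains of compound 3 and compound 1 cannot be ordered, and both stand apart from compound 2. Nothing measured here bears on the cause of these steps. Open, from the compounds shown here alone, is whether a longer chain than that of compound 1 holds this level, and whether a chain carrying an amine or a carboxylic acid does.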